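Amide-linked flavone ethers: antiproliferative notes

The source may hold more compounds than are shown below. What is called first, only, known or untested is meant among the compounds shown, and "the series" means these compounds.

Measured so far:
compound 1 `O=C(COc1ccc2oc(-c3ccccc3)cc(=O)c2c1)Nc1ccc2ccccc2c1` — 6750 nM
compound 2 `O=C(COc1c(-c2ccccc2)oc2ccccc2c1=O)Nc1ccc(F)cc1` — 9500 nM

In a functional assay on NPC-TW01 cells (Homo sapiens) for antiproliferative activity, read by MTT assay, with a stated time of 72 h (a higher number here means a weaker inhibitor of growth, a lower number a stronger inhibitor of growth), compound 1 gives 6750 nM, the lower of the two numbers; compound 2 gives 9500 nM, and the gap between them lies within the scatter, so no order can be read from it. Compound 3 `COc1ccc(NC(=O)COc2ccc3oc(-c4ccccc4)cc(=O)c3c2)cc1` has not been measured. It differs from compound 1 in one place: 4-methoxyphenyl in place of naphthalen-2-yl on an amide-type nitrogen. No step between measured compounds covers this change, so the expectation rests on the weak level shown by compound 1 alone. For compound 3 in this assay a step of a 1.3-fold higher number from compound 1 to compound 3 (0.12 log units; within the scatter) is expected, no larger than the scatter in either direction, and the estimate is 9000 nM, with a range from 3500 nM to 25000 nM.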

Compound 3, concentration for 50% growth inhibition: 710 nM
Compound 3: the middle estimate sits 13-fold (1.10 log units) above what was measured; the whole stated range lies above it.
By their numbers in this assay, from the lowest: compound 3; then compounds 1 and 2 (each within the scatter of the next).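

In this assay, among the compounds shown here, 4-methoxyphenyl in place of naphthalen-2-yl gives a 9.5-fold lower number from compound 1 to compound 3 (0.98 log units; beyond the scatter), the first single-place change and one that lies beyond the scatter. Compounds 1 and 2 differ in more than one place and could not show that the group on the amide-type nitrogen affects growth inhibition on the shared core of compound 1. Nothing available explains this step.

Open, as far as these compounds go, is whether the methoxy group matters or a single aromatic ring is enough, which unsubstituted phenyl or 4-aminophenyl on the same nitrogen would help separate. Also open, from the compounds shown here alone, is whether the step carries over to the core of compound 2.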